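The compounds below may be only part of what the source reports. "The series", "measured", "known", "first", "only" and "open" are said of these compounds alone.

In a functional assay on NCI-H460 cells (Homo sapiens) for cytotoxicity, read by MTT assay, with a stated time of 96 h (on this read-out higher numbers stand for weaker inhibition and lower numbers for stronger inhibition), compound 3 `CNc1nc(C)c2cc(-c3cnc(OC)c(NS(=O)(=O)c4ccc(F)cc4F)c3)cc(OC3CCOC(C)(C)C3)c2n1` gives 250 nM. Compound 2 `CNc1nc(C)c2cc(-c3cnc(OC)c(NS(=O)(=O)c4ccc(F)cc4F)c3)cc(OCC3CCOC3)c2n1` gives 310 nM, which lies within the scatter of compound 3. Compound 1 `COc1ncc(-c2cc(OC3CCCCC3)c3nc(N)nc(C)c3c2)cc1NS(=O)(=O)c1ccc(F)cc1F` gives 96 nM, a lower number than the other two and beyond the scatter from compound 3. Compound 4 `CNc1nc(C)c2cc(-c3cnc(OC)c(NS(=O)(=O)c4ccc(F)cc4F)c3)cc(OC3CCCCC3)c2n1` departs from compound 3 in one place: cyclohexyl in place of 2,2-dimethyloxan-4-yl on an oxygen on an aromatic ring. Thus cyclohexyl stands in place of 2,2-dimethyloxan-4-yl on an oxygen on an aromatic ring. One measured step changes that same place: a 1.2-fold lower number from compound 2 to compound 3 (0.09 log units; within the scatter). It shows that a swap there can leave the number almost unmoved. Compound 1 also carries cyclohexyl on that oxygen, but it differs from compound 4 elsewhere, so it offers a hint rather than a clean comparison. With compound 1 at 96 nM, a modest move to a lower number is expected, and it may not clear the scatter. The expected change is a 1.7-fold lower number from compound 3 to compound 4 (0.22 log units; within the scatter). For compound 4 the estimated value is 150 nM, with an expected range from 70 nM to 320 nM.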

Compound 4, half-maximal inhibitory concentration: 1700 nM
Compound 4: middle estimate off by 11-fold (1.05 log units), on the low side, outside the stated range (above it).
By their numbers in this assay, from the lowest: compound 1; then compounds 3 and 2 (each within the scatter of the next); then compound 4.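

In this assay the oxygen on the aromatic ring proves sensitive to what it carries: cyclohexyl in place of 2,2-dimethyloxan-4-yl gives a step beyond the scatter (a 6.8-fold higher number from compound 3 to compound 4 (0.83 log units; beyond the scatter)), and cyclohexyl in place of (oxolan-3-yl)methyl gives another (a 5.5-fold higher number from compound 2 to compound 4 (0.74 log units; beyond the scatter)), although compounds 2 and 3 lie within the scatter of each other. With cyclohexyl held constant, methyl in place of hydrogen on the nitrogen on an aromatic ring gives a large step (an 18-fold higher number from compound 1 to compound 4 (1.25 log units; beyond the scatter)), so the low number of compound 1 did not carry over to compound 4. Nothing available here explains these steps.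

The compounds shown leave open whether hydrogen on that nitrogen would also lower the numbers of compounds 2 and 3. They also leave open where a piperidine or a longer carbon chain on the oxygen would fall.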